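The source may hold more compounds than are shown below. What is called first, only, known or untested is meant among the compounds shown, and "the series" means these compounds.

In a functional assay on HT-29 cells (Homo sapiens) for cytotoxicity (a lower number here means a stronger inhibitor, a higher number a weaker inhibitor), compound 1 `COc1ccc(S(=O)(=O)N2CCc3cccc(NCc4ccccc4)c32)cc1` gives only a limit, > 10000 nM. Within the data shown here, that is the limit (the limit of > 10000 nM in this assay, at which 1 of the 2 values shown sits), so of the two values shown only one is a number. Among the measured compounds shown here, compound 2 `COc1ccc(S(=O)(=O)N2CCc3cccc(NC(=O)c4ccco4)c32)cc1` gives 9.5 nM in this assay, and it therefore stands as the sole numbered compound, with nothing measured to set beside it.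

Compound 3 `COc1ccc(S(=O)(=O)N2CCc3cccc(NC(=O)c4ccc(F)cc4)c32)cc1` differs from compound 2 on the carbonyl carbon: 4-fluorophenyl in place of furan-2-yl on a carbonyl carbon. For the measured compounds named here, the one measured step, an at least 1000-fold lower number from compound 1 to compound 2 (3.02 log units; beyond the scatter), swaps benzyl for (furan-2-yl)carbonyl on the ring nitrogen; it does not test a change of the ring on the carbonyl carbon, and it bears on compound 3 only in showing that the carbonyl pattern shared by compound 2 and compound 3 reaches a low number. The step of a 1.6-fold higher number from compound 2 to compound 3 (0.20 log units; within the scatter) is thus expected to be small, within or near the scatter. Compound 3 is estimated at 15 nM, between 3 nM and 80 nM.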

Compound 3, half-maximal inhibitory concentration: 55 nM
Beside the measured number, compound 3's estimate is 3.7-fold (0.56 log units) below it; measured number inside the range.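

Among these compounds, compound 3 shows that the ring on the carbonyl carbon matters in this assay: a 5.8-fold higher number from compound 2 to compound 3 (0.76 log units; beyond the scatter), so 4-fluorophenyl in place of furan-2-yl gives a modest but real change that the earlier compounds could not show. The second carbonyl compound also stands far from the benzyl compound, an at least 180-fold lower number from compound 1 to compound 3 (2.25 log units; beyond the scatter), so the low numbers are not tied to furan-2-yl alone. Compound 1 gives a limit and not a number, so this large step has no exact size: the limit of > 10000 nM in this assay, at which 1 of the 3 values shown sits.

The two rings differ at once in ring size, in the ring oxygen and in the fluorine, and the compounds shown do not tell these apart. An unsubstituted phenyl or a thiophen-2-yl on the carbonyl carbon would bear on that question.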